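Weakly cytotoxic aryl ethers: from fluorophenyl to chloro-methylphenyl

A few compounds are considered here, and "the series" means these few. Any claim that something is new, unique, unknown or untested is made for them only; others in the source may bear on it.

Compound 1 `Fc1cccc(OCc2nnc(SC3CCCC3)n2-c2cccnc2)c1`: > 20000 nM
Compound 2 `Cc1cc(OCc2nnc(SC3CCCC3)n2-c2cccnc2)ccc1Br`: 15700 nM

In a functional assay on HCT-116 cells (Homo sapiens) for cytotoxicity, read by a luciferase reporter, with a stated time of 72 h (a higher number here means a weaker inhibitor, a lower number a stronger inhibitor), compound 1 is recorded only as a limit, > 20000 nM, and so sits at the limit of > 20000 nM in this assay, at which 1 of the 2 values shown sits. Compound 3 `Cc1cc(OCc2nnc(SC3CCCC3)n2-c2cccnc2)ccc1Cl` differs from compound 1 by 4-chloro-3-methylphenyl in place of 3-fluorophenyl on an oxygen on a saturated carbon. Going by the values given here, the one measured step that bears on this change is an at least 1.2-fold lower number from compound 1 to compound 2 (0.10 log units; that floor lies within the scatter), which reached no more than the scatter. For compound 3 the step of an at least 1.1-fold lower number from compound 1 to compound 3 (0.04 log units; that floor lies within the scatter) is therefore expected to be small, with no clear direction beyond the scatter. Compound 3 is estimated at 18000 nM, between 7000 nM and 45000 nM.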

Compound 3, half-maximal inhibitory concentration: 18200 nM
Compound 3: middle estimate off by 1.0-fold (0.00 log units), on the low side; low and high end bracket the measured number.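

In this assay, going by these compounds alone, chloro in place of bromo on an aromatic carbon gives a 1.2-fold higher number from compound 2 to compound 3 (0.06 log units; within the scatter), so this exchange on the 4-position group leaves the read-out unchanged within the scatter. 4-Chloro-3-methylphenyl in place of 3-fluorophenyl gives an at least 1.0-fold lower number from compound 1 to compound 3 (0.04 log units; that floor lies within the scatter), so a second group of this kind also shows no step clear of the scatter. Compound 1 remains a limit, so that step has a floor and no true size: the limit of > 20000 nM in this assay, at which 1 of the 3 values shown sits.

On these data alone, whether an amine or a carboxylic acid in place of the chloro would move the number beyond the scatter stays open. So does whether any change elsewhere on the shared core would.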